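Trimming a Hydroxyhexyl Tail Down to Allyl

A few compounds are considered here, and "the series" means these few. Any claim that something is new, unique, unknown or untested is made for them only; others in the source may bear on it.

In an assay (Cricetulus griseus) for inhibition of aldehyde dehydrogenase, mitochondrial (Homo sapiens) (on this read-out higher numbers stand for weaker inhibition and lower numbers for stronger inhibition), compound 1 `O=c1c(-c2ccc(O)cc2)coc2cc(OCCOCCOCCO)ccc12` gives 40 nM. Compound 2 `NCCCCCCOc1ccc2c(=O)c(-c3ccc(O)cc3)coc2c1` gives 100 nM, and compound 3 `O=c1c(-c2ccc(O)cc2)coc2cc(OCCCCCCO)ccc12` gives 120 nM, the highest number of the three. Replacing the ether-containing tail with a plain hydroxyalkyl chain raised the number: a 3.0-fold higher number from compound 1 to compound 3 (0.48 log units; beyond the scatter), while swapping the terminal amine for a hydroxyl hardly mattered: a 1.2-fold higher number from compound 2 to compound 3 (0.08 log units; within the scatter). Compound 4 `C=CCOc1ccc2c(=O)c(-c3ccc(O)cc3)coc2c1` has not yet been measured; it differs from compound 3 by vinyl in place of 5-hydroxypentyl on a saturated chain carbon bound to an oxygen on an aromatic ring. Both earlier changes to this tail left the number near compound 3 or moved it modestly, so a modest step toward weaker inhibition is expected: a 1.8-fold higher number from compound 3 to compound 4 (0.26 log units; within the scatter). Compound 4 is therefore estimated at 220 nM, with a likely range from 80 nM to 650 nM.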

Compound 4, half-maximal inhibitory concentration: 180 nM
The estimate for compound 4 lay 1.2-fold (0.09 log units) above the measured number; measured number inside the range.
By their numbers in this assay, from the lowest: compound 1; then compounds 2, 3 and 4 (each within the scatter of the next).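

In this assay, the short allyl tail does not separate from the longer tails ending in hydroxy or amino: a 1.5-fold higher number from compound 3 to compound 4 (0.18 log units; within the scatter), and a 1.8-fold higher number from compound 2 to compound 4 (0.26 log units; within the scatter). At this place, then, losing the chain end with its hydrogen-bond donor and acceptor gives no step beyond the scatter, whereas the tail of compound 1 does stand apart: a 4.5-fold higher number from compound 1 to compound 4 (0.65 log units; beyond the scatter). Nothing measured here offers a reason for these steps. Open, from the compounds shown here alone, is whether a carboxylic acid at the chain end would separate from these tails, and whether a longer chain with more ether oxygens would go below compound 1.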